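Chloro on the biphenyl ring: compound 2 to compound 3

The source may hold more compounds than are shown below. What is called first, only, known or untested is meant among the compounds shown, and "the series" means these compounds.

Measured so far:
compound 1 `CCOc1cc(C)c(-c2cccc(COc3ccc(NCC(=O)O)c(F)c3)c2)c(C)c1` — > 1000 nM
compound 2 `O=C(O)COc1ccc(NCc2cccc(-c3ccccc3)c2)cc1F` — 58.5 nM

Compound 1, with the structure `CCOc1cc(C)c(-c2cccc(COc3ccc(NCC(=O)O)c(F)c3)c2)c(C)c1`, reaches only the assay limit of > 1000 nM in a functional assay on CHO cells for agonist activity at Free fatty acid receptor 1 (Homo sapiens), read by FLIPR and calcium flux; on this read-out higher numbers stand for an effect only at larger amounts of compound and lower numbers for an effect already at smaller amounts; that value is a limit, not a number. Among the measured compounds shown here, compound 2, with the structure `O=C(O)COc1ccc(NCc2cccc(-c3ccccc3)c2)cc1F`, gives 58.5 nM in this assay, the only full number so far. The other entry, that of compound 1, is a limit (the limit of > 1000 nM in this assay, at which 1 of the 2 values shown sits). Compound 3, with the structure `O=C(O)COc1ccc(NCc2ccc(Cl)c(-c3ccccc3)c2)cc1F`, is not yet measured. It differs from compound 2 by chloro in place of hydrogen on an aromatic carbon. For the measured compounds named here, no measured pair with a single change of this kind exists, so the size of the step rests on expectation alone. A modest shift is expected, a 1.5-fold lower number from compound 2 to compound 3 (0.17 log units; within the scatter), in the direction of effect at somewhat smaller amounts, though a step of this size could still sit within the usual scatter. For compound 3 the expected value in this assay is 40 nM, with a range from 15 nM to 130 nM.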

Compound 3, half-maximal effective concentration: 51.7 nM
Beside the measured number, compound 3's estimate is 1.3-fold (0.11 log units) below it; the range from low to high includes it.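

In this assay, placing chloro on the aromatic carbon ortho to a phenyl group and para to a large group gives a 1.1-fold lower number from compound 2 to compound 3 (0.05 log units; within the scatter). Among the compounds shown here, this is the first pair that differs in one place, and it shows that this position can carry a single chlorine atom with no difference from hydrogen that can be told from the scatter. No measurement at hand bears on why the two compounds read alike.

As far as these compounds go, whether the same holds for other groups at this position, such as methoxy, trifluoromethyl, nitrile or an amine, remains open. One pair also leaves open whether chloro would read the same way on another aromatic carbon of the shared core, or on the phenyl group itself.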